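A few compounds are considered here, and "the series" means these few. Any claim that something is new, unique, unknown or untested is made for them only; others in the source may bear on it.

Three measured compounds share one core, and each carries a six-carbon chain ending in an acid or an ester on the ring nitrogen. Compound 1 `O=C(O)CCCCCN1C(=O)/C(=C2/C(=O)Nc3ccccc32)SC1=S` gives 9% in an assay for inhibition of histone acetyltransferase KAT2B (Homo sapiens), read by TR-FRET, with a stated time of 10 min, tested at 50 uM; on this read-out higher numbers stand for more inhibition at the one concentration tested (going by the name of the read-out) and lower numbers for less inhibition. Compound 2 `COC(=O)CCCCCN1C(=O)/C(=C/c2cc(OC)ccc2OC)SC1=S` gives 21% in this assay, and compound 3 `CCOc1ccccc1/C=C1\SC(=S)N(CCCCCC(=O)OC)C1=O` gives 9%. On these numbers compound 1 stands level with compound 3 at the digits reported, and the two together are the lowest of the three; compound 2 is the furthest from compound 1, lying higher by a gap beyond the usual scatter. Among the measured compounds shown here, no pair of measured compounds differs in only one place, so no single step can be read off.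

Compound 4 `O=C(O)CCCCCN1C(=O)/C(=C2/C(=O)N(Cc3ccccc3)c3ccccc32)SC1=S` has not yet been measured. It differs from compound 1 in one place: benzyl in place of hydrogen on an amide-type nitrogen in a ring. For the measured compounds named here, no measured pair shows what such a change does to this read-out. With the three measured values all sitting low, a step of only modest size is expected, pointing slightly upward, and it may well fall within the scatter. The estimated step is a number 6 percentage points higher from compound 1 to compound 4 (within the scatter). Compound 4 is therefore expected to give 15% in this assay, within a range from 0% to 35%.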

Compound 4, a percentage reported as inhibition, at one concentration (the size of the read-out at that concentration, not a potency): 13%
For compound 4 the middle estimate is 2 percentage points above the measured one; the measured number falls inside the stated range.
By their numbers in this assay, from the lowest: compounds 1, 3, 4 and 2 (each within the scatter of the next, the first and the last beyond it).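

Benzyl in place of hydrogen on the amide-type nitrogen in a ring gives the first comparison in this assay that turns on one place alone, a number 4 percentage points higher from compound 1 to compound 4 (within the scatter), so the read-out does not separate the two compounds. The amide hydrogen can therefore be replaced at this position, even by a group bringing a six-membered aromatic ring of carbon only, without the number leaving the scatter around compound 1, though both compounds sit low and a low level says little about what the position can contribute. Nothing given here bears on why the step has this size.

The compounds shown leave open whether any group on this nitrogen can move the number beyond the scatter, for instance a methyl, or a benzyl carrying an amine or a carboxylic acid on its ring. Steps linking compound 4 to compound 2 or compound 3 cannot be read, and whether a methyl ester or a longer chain in place of the acid chain of compound 4 would change its number also stays open.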